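This account rests on a few compounds, and the source may have more. Where it says the series, first, only, none or still open, it means among the compounds named here.

Working notes on a small series tested in a functional assay on HT-1080 cells (Homo sapiens) for cytotoxicity; on this read-out lower numbers stand for an effect already at smaller amounts and higher numbers for an effect only at larger amounts of compound. Compound 1 `C=CC(C)(CC/C=C(\C)C(=O)O)O[C@@H]1O[C@H](C)[C@@H](O)[C@H](O)[C@H]1O` is the reference point of the step followed here. In this assay compound 1 gives > 100 ug/mL, which is a limit of the assay and not a number. For the measured compounds named here, compound 2 `C=CC1(C)CCC(C(CO)C(=O)O)O1` is the only other measured member. In this assay compound 2 gives > 100 ug/mL, again a limit rather than a number. Going by the values given here, compound 1 therefore stands at the limit, together with every other value so far: the limit of > 100 ug/mL in this assay, at which 2 of the 2 values shown sit. Among the compounds with values here, no pair of measured compounds differing in one place is available, so no measured step shows how the series answers to a change.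

Compound 3 `C=CC(C)(CC/C=C(\CO)C(=O)O)O[C@@H]1O[C@H](C)[C@@H](O)[C@H](O)[C@H]1O` is not yet measured. It differs from compound 1 in this way: hydroxy in place of hydrogen on a saturated chain carbon bound to a double-bonded chain carbon. Within the data shown here, with compound 1 sitting at a limit and no measured step to point in either direction, the expected step in this assay is a number no higher from compound 1 to compound 3 (the limit leaves the size open), that is, none beyond the scatter. Compound 3 is thus expected to come out near the limit again. Compound 3 is estimated at 100 ug/mL, with a range from 40 ug/mL to 300 ug/mL.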

Compound 3, concentration for half-maximal effect: > 100 ug/mL
Compound 3: a limit, no number; the forecaster's own chance of this, stated with the estimate: 85%; the middle value lies on the limit itself.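

In this assay, for the compounds shown here, compound 3 gives > 100 ug/mL, a limit of the assay and not a number; with compound 1 also at a limit, no step between the two can be read. The compounds shown leave open whether any structural change, this hydroxy in place of hydrogen included, moves the read-out at all, with every value standing at one limit: the limit of > 100 ug/mL in this assay, at which 3 of the 3 values shown sit.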